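From a Methylamide Chain to an Ethyl Ester

The source may hold more compounds than are shown below. What is called first, only, known or untested is meant among the compounds shown, and "the series" means these compounds.

Compound 1 `CNC(=O)CCc1ccncc1-c1ccc2ccccc2c1` carries a 2-(methylcarbamoyl)ethyl group on its core. In a functional assay on HCT-116 cells (Homo sapiens) for inhibition, read by MTT assay, with a stated time of 72 h (on this read-out higher numbers stand for weaker inhibition of growth and lower numbers for stronger inhibition of growth), compound 1 gives 19300 nM and is the only one of the three measured compounds to give a number at all. Compound 2 `O=C(O)/C=C/c1ccncc1-c1ccc2[nH]ccc2c1` reaches only a limit in this assay, namely > 30000 nM and no number. Compound 3 `Cn1ncc2cc(-c3cnccc3/C=C/C(=O)O)ccc21` also stops at a limit in this assay, > 30000 nM being the most that can be said of it. Going by the values given here, two of the three values therefore sit at the limit of > 30000 nM in this assay, at which 2 of the 3 values shown sit, and no two measured compounds differ in a single place, so no measured step is available to guide expectations.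

Compound 4 `CCOC(=O)/C=C/c1ccncc1-c1ccc2ccccc2c1` differs from compound 1 in one spot: 2-(ethoxycarbonyl)ethenyl in place of 2-(methylcarbamoyl)ethyl on an aromatic carbon on an aromatic carbon of the six-membered aromatic ring with one nitrogen, opposite the ring nitrogen. Given that compound 1 gives 19300 nM, the step from compound 1 to compound 4 is expected to stay within the scatter or lean toward weaker inhibition, a 1.0-fold higher number from compound 1 to compound 4 (0.02 log units; within the scatter) being the estimate. Compound 4 is expected to give 20000 nM in this assay, with a range from 6000 nM to 30000 nM allowed.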

Compound 4, concentration for 50% growth inhibition: 910 nM
For compound 4 the middle estimate is 22-fold (1.34 log units) above the measured one, and the stated range ends above it.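

In this assay, the group on the aromatic carbon opposite the ring nitrogen clearly matters, as the change gives a 21-fold lower number from compound 1 to compound 4 (1.33 log units; beyond the scatter), and here a lower number means stronger inhibition of growth. This single swap alters more than one feature, since 2-(ethoxycarbonyl)ethenyl has an ester in place of the amide, has no hydrogen-bond donor, and brings a second double bond outside the aromatic rings. Nothing measured among the compounds shown explains why the number falls.

Which of these features carries the step remains open, and 2-(ethoxycarbonyl)ethyl, the same ester on a chain without the ring-side double bond, and 2-(methylcarbamoyl)ethenyl, the amide with that double bond, would separate them. Whether a methyl ester or a longer ester would hold this level of inhibition is also unknown.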